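Extending the Chain on a Weak Silyl Cyanohydrin Inhibitor

The compounds below may be only part of what the source reports. "The series", "measured", "known", "first", "only" and "open" are said of these compounds alone.

The study examines two silylated cyanohydrins in an assay on isolated protein for inhibition of Phenylethanolamine N-methyltransferase (Bos taurus); on this read-out lower numbers stand for stronger inhibition and higher numbers for weaker inhibition. Compound 1, `CCCCCCC(C#N)O[Si](C)(C)C`, carries a hydrogen on the carbon bearing the nitrile and the silyl ether oxygen; in this assay compound 1 gives 109000 nM. Compound 2, `CCCCCC(C)(C#N)O[Si](C)(C)C`, carries a methyl on that carbon with a shorter chain; in this assay compound 2 gives 669000 nM. Of the two numbers, compound 2 stands at the higher one, and the gap to compound 1 lies beyond the usual scatter. Within the data shown here, since compound 1 and compound 2 differ in two places, the two values show only that the pair of changes together leads to the higher number.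

Compound 3, `CCCCCCC(C)(C#N)O[Si](C)(C)C`, is not yet measured. It differs from compound 2 by methyl in place of hydrogen on a saturated chain carbon, six bonds along the chain from an oxygen on an unsaturated carbon and a triple-bonded carbon, so the change reads as a lengthening of the chain by one carbon while the methyl on the nitrile-bearing carbon stays. Among the measured compounds shown here, no measured pair in this set isolates that change. The authors expect a small step in this assay, if any beyond the scatter, with no firm direction. For compound 3 the estimate is 500000 nM, between 200000 nM and 1500000 nM, which would be a step of a 1.3-fold lower number from compound 2 to compound 3 (0.13 log units; within the scatter).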

Compound 3, half-maximal inhibitory concentration: 664000 nM
Compound 3: middle estimate off by 1.3-fold (0.12 log units), on the low side; measured number inside the range.
By their numbers in this assay, from the lowest: compound 1; then compounds 3 and 2 (each within the scatter of the next).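

In this assay, lengthening the chain by one carbon while the methyl on the nitrile-bearing carbon stays gives a 1.0-fold lower number from compound 2 to compound 3 (0.00 log units; within the scatter), so at this chain position, methyl in place of hydrogen leaves the number unchanged within the scatter. Among these compounds, compound 3 also allows the other change to be read alone for the first time: with the chain held constant, methyl in place of hydrogen on the carbon bearing the nitrile and the silyl ether oxygen gives a 6.1-fold higher number from compound 1 to compound 3 (0.78 log units; beyond the scatter), a step beyond the scatter that compound 1 and compound 2 could not isolate because they differ in two places. Across these three compounds, the higher numbers therefore go with the methyl on the nitrile-bearing carbon rather than with the added chain carbon, although nothing shown here accounts for either step.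

The compounds shown leave open whether an ethyl on the nitrile-bearing carbon would give a number like that of compound 3 or compound 1. They also leave open whether a longer chain, or a hydroxyl in place of the trimethylsilyl ether, would move the number in this series.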